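The compounds below may be only part of what the source reports. "The series", "measured", "known", "first", "only" and "open" are said of these compounds alone.

Compound 1 `CCOC(=O)/C=C1/SC(N2N=C(c3cc4ccccc4o3)CC2c2ccc(Cl)cc2)=NC1=O` carries an ethyl ester on the exocyclic double bond of its core. In a functional assay on A549 cells (Homo sapiens) for antiproliferative activity, read by MTT assay, with a stated time of 96 h (on this read-out lower numbers stand for stronger inhibition and higher numbers for weaker inhibition), compound 1 gives > 5 ug/mL, which is a limit of the assay rather than a number. Compound 1 thus sits at the limit of > 5 ug/mL in this assay, at which 1 of the 3 values shown sits. Its two measured companions differ only in the aryl group on the saturated ring: compound 2 `CCOC(=O)/C=C1/SC(N2N=C(c3cc4ccccc4o3)CC2c2ccc(OC)c(OC)c2)=NC1=O` gives 3.42 ug/mL and compound 3 `CCOC(=O)/C=C1/SC(N2N=C(c3cc4ccccc4o3)CC2c2ccc(OC)cc2)=NC1=O` gives 1.21 ug/mL in this assay. Those pairs yield an at least 1.4-fold lower number from compound 1 to compound 2 (0.16 log units; that floor lies within the scatter), an at least 4.1-fold lower number from compound 1 to compound 3 (0.61 log units; beyond the scatter) and a 2.8-fold lower number from compound 2 to compound 3 (0.45 log units; beyond the scatter).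

Compound 4 `COC(=O)/C=C1/SC(N2N=C(c3cc4ccccc4o3)CC2c2ccc(Cl)cc2)=NC1=O` differs from compound 1 in a different place: hydrogen in place of methyl on a saturated chain carbon bound to an oxygen next to a carbonyl group, that is, ethoxycarbonyl to methoxycarbonyl. Among the measured compounds shown here, none of the three measured steps touches the ester, so no step gives direct guidance on this change. Lacking any such step, a step of no size beyond the scatter is expected, namely a step that the limit leaves unreadable from compound 1 to compound 4. Compound 4 is therefore expected to give 7 ug/mL, with a plausible range from 3 ug/mL to 20 ug/mL in this assay.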

Compound 4, half-maximal inhibitory concentration: 1.08 ug/mL
Compound 4: middle estimate off by 6.5-fold (0.81 log units), on the high side, outside the stated range (below it).
By their numbers in this assay, from the lowest: compounds 4 and 3 (each within the scatter of the next); then compound 2. At a limit, above all of these: compound 1.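

The earlier steps shown here all changed the aryl group on the saturated ring, and this result shows that the ester on the exocyclic double bond also counts. In this assay, going from ethoxycarbonyl to methoxycarbonyl, which swaps one methyl for a hydrogen, gives an at least 4.6-fold lower number from compound 1 to compound 4 (0.66 log units; beyond the scatter), so even this small edit at the ester moves the read-out beyond the usual scatter. The true size of that step stays unknown, since compound 1 gives a limit and not a number: the limit of > 5 ug/mL in this assay, at which 1 of the 4 values shown sits.

Going by these compounds, it remains open whether the methoxycarbonyl group would bring a similar step alongside the aryl groups of compound 2 and compound 3. Also open, on these data alone, is how a carboxylic acid, or a longer chain such as a propyl ester, would read at this place.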